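Swapping a fluorobenzyl for a nitrile chain: expected tolerance

A few compounds are considered here, and "the series" means these few. Any claim that something is new, unique, unknown or untested is made for them only; others in the source may bear on it.

Compound 2 `Cc1cc(C)c(Oc2cc(Nc3ccc(C#N)cc3)ncc2C(=O)NCc2cn(Cc3ccc(F)cc3)nn2)c(C)c1` stands only at a limit in an ADME assay on MT4 cells (Homo sapiens) for cytotoxicity, read by MTT assay, with a stated time of 5 days; a higher number here means that more compound is tolerated, a lower number that less compound is tolerated. In this assay compound 2 gives >= 153000 nM, which is a limit of the assay and not a number. Compound 1 `Cc1cc(C)c(Oc2cc(Nc3ccc(C#N)cc3)ncc2C(=O)NCc2cn(Cc3cccc(F)c3)nn2)c(C)c1` likewise gives only a limit in this assay, >= 204000 nM. Going by the values given here, the single measured step, a step that the two limits leave unreadable from compound 1 to compound 2, is thus unreadable. Compound 3 `Cc1cc(C)c(Oc2cc(Nc3ccc(C#N)cc3)ncc2C(=O)NCc2cn(CCC#N)nn2)c(C)c1` differs from compound 2 by cyanomethyl in place of 4-fluorophenyl on a saturated chain carbon bound to an aromatic nitrogen. Among the compounds with values here, no measured step bears on this change, so compound 3 is expected to stay at the limit, and the step that the limit leaves unreadable from compound 2 to compound 3 is expected to lie within the scatter. The estimate for compound 3 is 180000 nM, with a range from 80000 nM to 400000 nM.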

Compound 3, half-maximal cytotoxic concentration: 40200 nM
For compound 3 the middle estimate is 4.5-fold (0.65 log units) above the measured one; measured number outside the range, below it.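

In this assay, compound 3 is the first compound shown to give a number and not a limit, so the group on a saturated chain carbon bound to an aromatic nitrogen does bear on this read-out. Cyanomethyl in place of 4-fluorophenyl gives an at least 3.8-fold lower number from compound 2 to compound 3 (0.58 log units; beyond the scatter), and cyanomethyl in place of 3-fluorophenyl gives an at least 5.0-fold lower number from compound 1 to compound 3 (0.70 log units; beyond the scatter). As far as these compounds go, both steps start from a limit of the assay, so their full size stays unknown.

From the compounds shown here alone, whether the nitrile or the loss of the aromatic ring carries these steps stays open. A plain propyl chain in this place would separate the two.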